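Swapping the halogenated aryl amine on a shared core

The source may hold more compounds than are shown below. What is called first, only, known or untested is meant among the compounds shown, and "the series" means these compounds.

Compound 1 `Cc1n[nH]c2ccc(-c3nc4cnc(N5CCN(C)CC5)cn4c3Nc3ccccc3F)cc12`: 0%
Compound 2 `Cc1n[nH]c2ccc(-c3nc4cnc(N5CCN(C)CC5)cn4c3Nc3ccccc3)cc12`: "not determined" (no result reported)
Compound 3 `Cc1n[nH]c2ccc(-c3nc4cnc(N5CCN(C)CC5)cn4c3Nc3ccc(Br)cc3Cl)cc12`: "not determined" (no result reported)

Compound 1 carries a 2-fluorophenyl on the amine nitrogen of the shared core, and in a functional assay on CWR22R cells (Homo sapiens) for inhibition, with a stated time of 120 h, tested at 10 uM (on this read-out higher numbers stand for more inhibition at the one concentration tested (going by the name of the read-out) and lower numbers for less inhibition), compound 1 gives 0%. Compound 2 and compound 3 share that core; compound 3 carries the 4-bromo-2-chlorophenyl group, but in this assay compound 2 gives "not determined" (no result reported) and compound 3 gives "not determined" (no result reported), so compound 3 stands without a number on the read-out shown. Compound 4 `Cc1n[nH]c2ccc(-c3nc4cnc(N5CCN(C)CC5)cn4c3Nc3ccc(F)cc3Br)cc12` is the next member to be measured. The change from compound 3 to compound 4 is 2-bromo-4-fluorophenyl in place of 4-bromo-2-chlorophenyl on a nitrogen on an aromatic ring. Among the measured compounds shown here, with no measured step in the set, there is no precedent against which to size this move; the only reported number, that of compound 1, is zero. Given that compound 1 gives 0%, compound 4 is expected to lie low as well, near 10%, with an estimated range from 0% to 40%, and any difference from the scatter of this assay is expected to be small at most.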

Compound 4, a percentage reported as inhibition, at one concentration (the size of the read-out at that concentration, not a potency): 4.41%
Compound 4: middle estimate off by 5.6 percentage points, on the high side, and the stated range covers the measured number.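

In this assay the shared core now has a second number, and placing 2-bromo-4-fluorophenyl in place of 2-fluorophenyl on a nitrogen on an aromatic ring gives a number 4.4 percentage points higher from compound 1 to compound 4 (within the scatter) with no separation between the two compounds. The change from 4-bromo-2-chlorophenyl to 2-bromo-4-fluorophenyl cannot be read, since compound 3 has no number. Nothing measured here speaks to why these two halogenated groups give the values they do.

The compounds shown leave open whether any group on this nitrogen can lift the read-out beyond the scatter, as the unsubstituted phenyl of compound 2 also has no number. A phenyl ring carrying a methoxy group or a carboxylic acid, or a saturated amine such as morpholine in place of the aryl ring, would test that question.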